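Swapping the sulfanyl side group of compound 2

The source may hold more compounds than are shown below. What is called first, only, known or untested is meant among the compounds shown, and "the series" means these compounds.

In a functional assay on PC-3 cells (Homo sapiens) for antiproliferative activity, read by MTT assay, with a stated time of 48 h (a lower number here means a stronger inhibitor, a higher number a weaker inhibitor), compound 1 `COc1ccc(CN(C(=O)CCSc2nc3ccccc3o2)c2cc(OC)c(OC)c(OC)c2)cc1` gives 20200 nM, and compound 2 `COc1ccc(CN(C(=O)CCCSc2nc3ccccc3o2)c2cc(OC)c(OC)c(OC)c2)cc1` gives 32700 nM. Within the data shown here, these two numbers lie within the scatter of each other, so compound 2 cannot be ranked against the only other compound measured so far.

Compound 3 `COc1ccc(CN(C(=O)CSc2nc3ccccc3[nH]2)c2cc(OC)c(OC)c(OC)c2)cc1` has not yet been measured. In it, (1H-benzimidazol-2-yl)sulfanyl stands in place of 2-((1,3-benzoxazol-2-yl)sulfanyl)ethyl on a saturated chain carbon bound to a carbonyl carbon ((1H-benzimidazol-2-yl)sulfanyl in place of 2-((1,3-benzoxazol-2-yl)sulfanyl)ethyl on a saturated chain carbon bound to a carbonyl carbon).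

Among the measured compounds shown here, only one measured step bears on this change: a 1.6-fold higher number from compound 1 to compound 2 (0.21 log units; within the scatter). That step altered the chain alone and stayed within the scatter, so it offers no sign of a large effect from the chain. For the measured compounds named here, no measured compound carries the (1H-benzimidazol-2-yl)sulfanyl group, so that part of the change is untested and could push the number either way. No step beyond the scatter is therefore expected in this assay, though with real uncertainty. The expected move is a 1.5-fold lower number from compound 2 to compound 3 (0.17 log units; within the scatter). For compound 3 the estimated value is 22000 nM, with an expected range of 5000 nM to 60000 nM.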

Compound 3, half-maximal inhibitory concentration: 14400 nM
Beside the measured number, compound 3's estimate is 1.5-fold (0.18 log units) above it, within the range that was stated.
By their numbers in this assay, from the lowest: compounds 3, 1 and 2 (each within the scatter of the next, the first and the last beyond it).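

In this assay, among these compounds, placing (1H-benzimidazol-2-yl)sulfanyl in the stead of 2-((1,3-benzoxazol-2-yl)sulfanyl)ethyl on a saturated chain carbon bound to a carbonyl carbon gives a 2.3-fold lower number from compound 2 to compound 3 (0.36 log units; beyond the scatter), the first step in this small set to pass beyond the scatter, though only modestly. Set against compound 1, the same group gives a 1.4-fold lower number from compound 1 to compound 3 (0.15 log units; within the scatter), so compound 3 cannot be told apart from compound 1 and its edge holds against compound 2 alone. No measured evidence is available to explain either step.

Compound 3 differs from compound 2 in both the heteroaromatic group and the length of the chain, so the compounds shown cannot say which of the two changes accounts for the step. Also open, going by these compounds, is how the number would respond to a quite different group at this place, such as an amine or a carboxylic acid, in the stead of the sulfanyl-linked groups compared here.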